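A few compounds are considered here, and "the series" means these few. Any claim that something is new, unique, unknown or untested is made for them only; others in the source may bear on it.

Measured in a functional assay on microsomes from liver (Rattus norvegicus, strain Wistar) for inhibition, with a stated time of 15 min; on this read-out higher numbers stand for weaker inhibition and lower numbers for stronger inhibition:
- Compound 1 `COc1cc(C2CC(c3cc4ccccc4o3)=NN2C(=O)Nc2ccc(F)cc2)ccc1O`: 125000000 nM
- Compound 2 `COc1cc(C2CC(c3cc4ccccc4o3)=NN2C(=O)Nc2ccc(Br)cc2)ccc1O`: 115000000 nM

Within the data shown here, only two compounds have been measured so far, and they cannot be told apart. Compound 2 gives 115000000 nM, level with compound 1 once the usual scatter of repeat measurements is taken into account. Among the measured compounds shown here, the one measured step is a 1.1-fold lower number from compound 1 to compound 2 (0.04 log units; within the scatter), which replaces fluoro with bromo at the same place on the aromatic ring.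

The next compound to be tested is compound 3 `COc1cc(C2CC(c3cc4ccccc4o3)=NN2C(=O)Nc2ccc(O)cc2)ccc1O`. Its change is hydroxy in place of bromo on an aromatic carbon.

For the measured compounds named here, only the step of a 1.1-fold lower number from compound 1 to compound 2 (0.04 log units; within the scatter) bears on this change, and it gives limited guidance. It shows that this position tolerated one swap without a measurable shift, but neither compound 1 nor compound 2 carries a hydroxy group. The data therefore point to no particular direction, and no step beyond the scatter is expected, though the uncertainty is wide.

The estimated step is a 1.0-fold lower number from compound 2 to compound 3 (0.02 log units; within the scatter).

For compound 3, the expected value is 110000000 nM, with an estimated range of 35000000 nM to 300000000 nM.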

Compound 3, half-maximal inhibitory concentration: 15000000 nM
For compound 3 the middle estimate is 7.3-fold (0.87 log units) above the measured one; measured number below the stated range.
By their numbers in this assay, from the lowest: compound 3; then compounds 2 and 1 (each within the scatter of the next).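

In this assay, the position para to a large group turns out not to be indifferent to what sits there: the earlier swap between the two halogens changed nothing measurable, but hydroxy gives a 7.7-fold lower number from compound 2 to compound 3 (0.88 log units; beyond the scatter) and an 8.3-fold lower number from compound 1 to compound 3 (0.92 log units; beyond the scatter). Both steps lie beyond the scatter and point the same way, so compound 3 is the strongest inhibitor of the three, although the size of the gain is modest. Unlike bromo, hydroxy counts as a hydrogen-bond donor and acceptor, but that is only a difference in how the two groups are counted, and no measurement here explains the lower number.

Going by these compounds, what remains open is whether this gain belongs to hydroxy alone, or whether an amine, a methoxy group or a carboxylic acid at the same place would give a similar number. All three compounds also share the same core, so these values cannot show whether hydroxy would have the same effect on a different core or at another place on this aromatic ring.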